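An amino group added to compound 1

A few compounds are considered here, and "the series" means these few. Any claim that something is new, unique, unknown or untested is made for them only; others in the source may bear on it.

Measured so far in a functional assay on HEK293 cells (Homo sapiens) for cytotoxicity; on this read-out lower numbers stand for higher toxicity in this test and higher numbers for lower toxicity in this test:
- compound 1 `COc1ccc([C@H]2CC(=O)N(c3ccccc3)C2)cc1OC1CCCC1`: > 10000 nM
- compound 2 `COc1ccc([C@H]2CC(=O)N(c3ccccc3N)C2)cc1OC1CCCC1`: > 10000 nM

Compound 1 stands at a limit of this assay, with > 10000 nM reported instead of a number. Compound 2 also gives only a limit, > 10000 nM. The measurements so far therefore show (the limit of > 10000 nM in this assay, at which 2 of the 2 values shown sit), and neither compound has a readable value.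

The step in question leads from compound 1 to compound 3 `COc1ccc([C@H]2CC(=O)N(c3ccc(N)cc3)C2)cc1OC1CCCC1`, which has not yet been measured. The structural change is amino in place of hydrogen on an aromatic carbon. The same difference, cut one bond further out, reads phenyl to 4-aminophenyl.

Among the compounds with values here, one measured step bears on it, since compound 2 also carries amino in place of hydrogen on an aromatic carbon. That step reads a step that the two limits leave unreadable from compound 1 to compound 2, so it gives neither a size nor a direction. No step beyond the scatter is therefore expected in this assay, and a further limit is the likeliest report.

The expected step is a step that the limit leaves unreadable from compound 1 to compound 3.

The estimate for compound 3 is 20000 nM.

The range expected for compound 3 runs from 8000 nM to 60000 nM.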

Compound 3, half-maximal cytotoxic concentration: > 10000 nM
Compound 3 gave a limit, no number; the forecaster's own chance of this, stated with the estimate: 85%; the middle value lies beyond the limit too.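

In this assay compound 3 gives > 10000 nM, which is a limit and not a number. No step to compound 3 from compound 1 or compound 2 can be read, and the results stand as follows: the limit of > 10000 nM in this assay, at which 3 of the 3 values shown sit.

The compounds shown leave open whether amino in place of hydrogen changes this read-out at all.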